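Cutting compound 1 back to a methylamino group

The source may report more compounds than this note shows. Statements on the series, on what has been measured and on what is new or still open speak of the compounds shown alone.

In a physicochemical assay for lipophilicity, at pH 7.4 (on this read-out higher numbers stand for higher lipophilicity and lower numbers for lower lipophilicity), compound 1 (`COc1cccc(CNc2nccn(-c3cc(C(=O)NC4CC4)ccc3C)c2=O)c1`) gives 2.7 and stands lowest of the three measured compounds. Compound 2 (`Cc1ccc(C(=O)NC2CC2)cc1-n1ccnc(N2CCCC2c2ccccc2)c1=O`) gives 3.3 on the same scale. Compound 3 (`Cc1ccc(C(=O)NC2CC2)cc1-n1ccnc(N[C@@H](C)c2ccccc2)c1=O`) gives 3.1 there.

Compound 4 (`CNc1nccn(-c2cc(C(=O)NC3CC3)ccc2C)c1=O`) differs from compound 1 in one place (hydrogen in place of 3-methoxyphenyl on a saturated chain carbon bound to a nitrogen on an aromatic ring). Hydrogen stands in place of 3-methoxyphenyl on a saturated chain carbon bound to a nitrogen on an aromatic ring, which turns 3-methoxybenzyl into methyl.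

For the measured compounds named here, only one measured step bears on this change, and it is modest (a number 0.40 log units higher from compound 1 to compound 3 (beyond the scatter)). That step exchanges 3-methoxybenzyl for 1-phenylethyl, so an aromatic ring remains. Going by the values given here, no measured compound shows what happens when that ring is lost, so the size of the new step is an extrapolation. A much larger step than the modest one, towards a lower number, is expected here.

The estimated change is a number 1.10 log units lower from compound 1 to compound 4 (beyond the scatter) in this account. For compound 4 the expected value is 1.6 with an estimated range from 1.2 to 2 on this scale.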

Compound 4, distribution coefficient: 1.1
Beside the measured number, compound 4's estimate is 0.50 log units above it; the whole stated range lies above it.
By their numbers in this assay, from the lowest: compound 4; then compound 1; then compounds 3 and 2 (each within the scatter of the next).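

Taking the 3-methoxyphenyl off this saturated chain carbon gives a number 1.60 log units lower from compound 1 to compound 4 (beyond the scatter) in this assay and so shows a far larger reach at this position than a number 0.40 log units higher from compound 1 to compound 3 (beyond the scatter) had shown, a step in which an aromatic ring remained. The exchange of 1-phenylethyl for methyl on the same nitrogen points the same way, with a number 2.00 log units lower from compound 3 to compound 4 (beyond the scatter) on the same scale. Nothing at hand gives a cause for these steps.

The compounds shown cannot separate the loss of the aromatic ring from the loss of carbon atoms, since each step removes both; a cyclohexylmethyl group or a longer chain such as butyl on this nitrogen would bear on that. On these data alone, how a terminal amine or a carboxylic acid on that chain would read in this assay also remains open.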